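Amide Variation in a Nitro-Sulfonyl Piperidine Series

The source may report more compounds than this note shows. Statements on the series, on what has been measured and on what is new or still open speak of the compounds shown alone.

Compound 1 `CC(C)N(C(=O)C1CCN(C(=O)c2ccc(S(C)(=O)=O)c([N+](=O)[O-])c2)CC1)C(C)C`: in an assay on isolated protein for inhibition of vitamin D3 receptor (Homo sapiens), read by fluorescence polarization (on this read-out higher numbers stand for weaker inhibition and lower numbers for stronger inhibition), compound 1 gives > 60000 nM, which is a limit of the assay and not a number.
Compound 2 `CN1CCN(C(=O)C2CCN(C(=O)c3ccc(S(C)(=O)=O)c([N+](=O)[O-])c3)CC2)CC1`: in this assay compound 2 gives > 60000 nM, again only a limit.
Compound 3 `CN(Cc1ccccc1F)C(=O)C1CCN(C(=O)c2ccc(S(C)(=O)=O)c([N+](=O)[O-])c2)CC1`: in this assay compound 3 gives > 60000 nM, once more a limit.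

Compound 3 therefore stands at the limit of this assay, and so do both of its measured neighbours (the limit of > 60000 nM in this assay, at which 3 of the 3 values shown sit). No value has yet been resolved as a number for any of the three. The changes among them, a step that the two limits leave unreadable from compound 1 to compound 2, a step that the two limits leave unreadable from compound 1 to compound 3 and a step that the two limits leave unreadable from compound 2 to compound 3, are each left unreadable by the two limits that frame them, so neither size nor direction can be taken from any of them.

Compound 4 `CS(=O)(=O)c1ccc(C(=O)N2CCC(C(=O)N3CCc4ccccc43)CC2)cc1[N+](=O)[O-]` carries a single change relative to compound 3: 2,3-dihydro-1H-indol-1-yl in place of (2-fluorobenzyl)(methyl)amino on a carbonyl carbon. Within the data shown here, the only evidence bearing on this step comes from the three limits, which neither favour nor oppose a change beyond the scatter in this assay. Compound 4 is accordingly expected to give about 60000 nM in this assay, within the range 20000 nM to 200000 nM. The expected step from compound 3 is thus a number no higher from compound 3 to compound 4 (the limit leaves the size open), most probably reported again only as a limit.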

Compound 4, half-maximal inhibitory concentration: > 60000 nM
Compound 4 was reported as a limit; the forecaster's own chance of this, stated with the estimate: 80%; the middle value sits exactly at the limit.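

Compound 4 is again reported only as a limit, like compound 1, compound 2 and compound 3, so none of the steps from those three compounds to compound 4 can be read, in size or in direction: the limit of > 60000 nM in this assay, at which 4 of the 4 values shown sit.

The compounds shown leave open whether any amide on this shared core gives a resolved number in this assay, and how large any of these changes on the carbonyl carbon would be.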